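Straightening a Side Chain on the Shared Core

A few compounds are considered here, and "the series" means these few. Any claim that something is new, unique, unknown or untested is made for them only; others in the source may bear on it.

Three measured compounds share one core and differ only in the chain hanging from the carbon that is double-bonded to nitrogen. Compound 1 `CC(C)=NNc1nc(-c2cccc([N+](=O)[O-])c2)cs1` gives 1070 nM in an assay on isolated protein for inhibition of Amine oxidase [flavin-containing] A (Homo sapiens), read by fluorescence, with a stated time of 20 min; a lower number here means a stronger inhibitor, a higher number a weaker inhibitor. Compound 2 `CCC(CC)=NNc1nc(-c2cccc([N+](=O)[O-])c2)cs1` gives 24300 nM in this assay, and compound 3 `C/C(CC(C)C)=N/Nc1nc(-c2cccc([N+](=O)[O-])c2)cs1` gives 4410 nM. Compound 3 thus stands second highest of the three numbers, nearer to compound 1 than to compound 2: the step was a 4.1-fold higher number from compound 1 to compound 3 (0.62 log units; beyond the scatter), whereas a 5.5-fold lower number from compound 2 to compound 3 (0.74 log units; beyond the scatter) lies further off.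

Compound 4 `CCCC/C(C)=N\Nc1nc(-c2cccc([N+](=O)[O-])c2)cs1` differs from compound 3 by propyl in place of isopropyl on a saturated chain carbon bound to a carbon with a double bond to nitrogen; the two hold the same atoms joined differently. Among the measured compounds shown here, no measured step exchanges a branched chain for a straight one of equal size, so the nearest guides are a 23-fold higher number from compound 1 to compound 2 (1.36 log units; beyond the scatter), a large loss on enlarging the chain, and a 4.1-fold higher number from compound 1 to compound 3 (0.62 log units; beyond the scatter), a modest one. Since the size here does not change, only a modest move is expected, leaning weaker. Compound 4 is estimated at 5500 nM, within 1500 nM to 18000 nM. That expectation amounts to a step of a 1.2-fold higher number from compound 3 to compound 4 (0.10 log units; within the scatter).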

Compound 4, half-maximal inhibitory concentration: 6330 nM
The estimate for compound 4 lay 1.2-fold (0.06 log units) below the measured number, within the range that was stated.
By their numbers in this assay, from the lowest: compound 1; then compounds 3 and 4 (each within the scatter of the next); then compound 2.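

At this place on the chain, the branched and straight forms of the same atoms cannot be told apart in this assay: the change from isopropyl to propyl gives a 1.4-fold higher number from compound 3 to compound 4 (0.16 log units; within the scatter). The straight chain also sits where the branched one did relative to the two smaller-chained compounds, with a 5.9-fold higher number from compound 1 to compound 4 (0.77 log units; beyond the scatter) and a 3.8-fold lower number from compound 2 to compound 4 (0.58 log units; beyond the scatter), so a larger chain raises the number relative to compound 1 in compounds 3 and 4, yet compound 2 goes against any simple rule of size by carrying the highest number with a smaller chain than either. No supporting measurement is available to explain these numbers.

On these data alone, whether a longer chain such as hexyl would raise the number further remains open. So does the effect of an amine or a carboxylic acid at the end of the chain.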